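The source may report more compounds than this note shows. Statements on the series, on what has been measured and on what is new or still open speak of the compounds shown alone.

Compound 2 `Cc1ncc(-c2cc(NC(=O)c3ccc(OCc4ccccn4)cc3)c(C)cc2C)[nH]1` gives 2.8 in a physicochemical assay for lipophilicity; a higher number here means a more lipophilic compound, a lower number a more polar compound. Among the measured compounds shown here, the only other number measured belongs to compound 1 `Cc1cc(C)c(-c2ncc[nH]2)cc1NC(=O)c1ccc(OCc2ccccn2)cc1`, which gives 3.1 in this assay, and the step of a number 0.30 log units lower from compound 1 to compound 2 (within the scatter) lies within the scatter. Compound 3 `Cc1cc(C)c(-c2nc3ccccc3[nH]2)cc1NC(=O)c1ccc(OCc2ccccn2)cc1` has not yet been measured; it differs from compound 2 by 1H-benzimidazol-2-yl in place of 2-methyl-1H-imidazol-5-yl on an aromatic carbon. For the measured compounds named here, the step from compound 1 to compound 2 is the only one touching this ring and it was small, so no measured step covers a fused six-membered aromatic ring of carbon only. Compound 3 is nonetheless expected to give 3.9 in this assay, between 3.4 and 4.4. The expected step is a number 1.10 log units higher from compound 2 to compound 3 (beyond the scatter).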

Compound 3, distribution coefficient: > 3.5
Compound 3 was reported as a limit (the forecaster's own chance of this, stated with the estimate: 5%); the middle value does not contradict the limit.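

At this position, on an aromatic carbon ortho to a methyl group, the ring swap now moves the number in this assay beyond the scatter, which the earlier change of imidazole group did not do: the fused six-membered aromatic ring of carbon only gives a number at least 0.70 log units higher from compound 2 to compound 3 (beyond the scatter), and a number at least 0.40 log units higher from compound 1 to compound 3 (beyond the scatter). The hydrogen-bond donor and acceptor counts of the leaving and entering groups are the same in the step to compound 3. Compound 3 stands at a limit of the assay, not at a number: the limit of > 3.5 in this assay, at which 1 of the 3 values shown sits.

As far as these compounds go, how far past that limit compound 3 lies stays open, so neither step has a known full size. Also open, from the compounds shown here alone, is what an amine or a carboxylic acid on this aromatic carbon would give in this assay.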